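From a 2-fluorobenzyl to a 3-chlorobenzyl amide

The source may hold more compounds than are shown below. What is called first, only, known or untested is meant among the compounds shown, and "the series" means these compounds.

Compound 1 `CN(C(=O)c1cc2c(Cc3ccccc3)n[nH]c2cc1O)c1ccco1` gives 2500 nM
Compound 2 `CN(Cc1ccccc1F)C(=O)c1cc2c(Cc3ccccc3)n[nH]c2cc1O` gives 1500 nM

Among the measured compounds shown here, in a functional assay on A2780 cells (Homo sapiens) for antiproliferative activity, read by resazurin assay, with a stated time of 72 h (on this read-out lower numbers stand for stronger inhibition and higher numbers for weaker inhibition), compound 2 gives 1500 nM and so stands within the scatter of compound 1 at 2500 nM on the only two numbers available. Compound 3 `CN(Cc1cccc(Cl)c1)C(=O)c1cc2c(Cc3ccccc3)n[nH]c2cc1O` differs from compound 2 in one place (3-chlorophenyl in place of 2-fluorophenyl on a saturated chain carbon bound to an amide-type nitrogen), with 3-chlorophenyl in place of 2-fluorophenyl on a saturated chain carbon bound to an amide-type nitrogen. For the measured compounds named here, the one measured step on this nitrogen (a 1.7-fold lower number from compound 1 to compound 2 (0.22 log units; within the scatter)) put 2-fluorobenzyl in place of furan-2-yl and stayed within the scatter. Going by the values given here, no measured pair shows a change on the phenyl ring itself. No step beyond the scatter is therefore expected in this assay in either direction. The expected step (a 1.2-fold lower number from compound 2 to compound 3 (0.06 log units; within the scatter)) stays within the scatter. Compound 3 is expected at 1300 nM with an estimated range from 500 nM to 3200 nM in this measurement.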

Compound 3, half-maximal inhibitory concentration: 5300 nM
The estimate for compound 3 lay 4.1-fold (0.61 log units) below the measured number; the measured number lies above the stated range.
By their numbers in this assay, from the lowest: compounds 2 and 1 (each within the scatter of the next); then compound 3.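

In this assay, among the compounds shown here, the exchange of one halogen-bearing phenyl for another on a saturated chain carbon bound to an amide-type nitrogen gives the first step here beyond the scatter: a 3.5-fold higher number from compound 2 to compound 3 (0.55 log units; beyond the scatter). Set against furan-2-yl, 3-chlorobenzyl also gives a step beyond the scatter, a 2.1-fold higher number from compound 1 to compound 3 (0.33 log units; beyond the scatter), whereas 2-fluorobenzyl gave a 1.7-fold lower number from compound 1 to compound 2 (0.22 log units; within the scatter), so this position does not respond to every substituted benzyl group in the same way. No available evidence bears on the reason for this difference.

The halogen and its place on the phenyl ring change together between compound 2 and compound 3, so the compounds shown cannot separate the two. A 2-chlorobenzyl or 3-fluorobenzyl group would pull them apart, and an unsubstituted benzyl group would show how each halogen compares with none.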